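The compounds below may be only part of what the source reports. "The series", "measured", "known", "first", "only" and "open" are said of these compounds alone.

Measured in a functional assay on MCF7 cells (Homo sapiens) for antiproliferative activity, read by MTT assay, with a stated time of 72 h; a higher number here means a weaker inhibitor, a lower number a stronger inhibitor:
compound 1 `O=C1O[C@H]([C@@H](O)Cn2cc(-c3cccc(O)c3)nn2)C(OCc2ccccc2)=C1OCc1ccccc1`: 51800 nM
compound 2 `CCCCc1cn(C[C@H](O)[C@H]2OC(=O)C(OCc3ccccc3)=C2OCc2ccccc2)nn1`: 7910 nM
compound 3 `O=C1O[C@H]([C@@H](O)Cn2cc(CNS(=O)(=O)c3ccc(F)cc3)nn2)C(OCc2ccccc2)=C1OCc1ccccc1`: 26800 nM

Compound 3 stands second highest of the three. Its number sits close to that of compound 1, as a 1.9-fold lower number from compound 1 to compound 3 (0.29 log units; within the scatter) shows, while compound 2 lies further off, as a 3.4-fold higher number from compound 2 to compound 3 (0.53 log units; beyond the scatter) shows. Compound 4 `O=C1O[C@H]([C@@H](O)Cn2cc(CNS(=O)(=O)c3ccc(Cl)cc3)nn2)C(OCc2ccccc2)=C1OCc1ccccc1` differs from compound 3 by chloro in place of fluoro on an aromatic carbon. For the measured compounds named here, no measured step swaps one halogen for another; the steps seen, a 6.5-fold lower number from compound 1 to compound 2 (0.82 log units; beyond the scatter) and a 3.4-fold higher number from compound 2 to compound 3 (0.53 log units; beyond the scatter), exchange whole groups at the same aromatic carbon of the shared core, so they give little guidance on so small a change. The expected step is therefore a 1.2-fold lower number from compound 3 to compound 4 (0.09 log units; within the scatter), not beyond the scatter in either direction. Compound 4 is estimated at 22000 nM, with a range from 9000 nM to 60000 nM.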

Compound 4, half-maximal inhibitory concentration: 4170 nM
The estimate for compound 4 lay 5.3-fold (0.72 log units) above the measured number; the measured number lies below the stated range.
By their numbers in this assay, from the lowest: compounds 4 and 2 (each within the scatter of the next); then compounds 3 and 1 (each within the scatter of the next).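

In this assay, for the compounds shown here, a single halogen on the aromatic ring turns out to matter: chloro in place of fluoro (a 6.4-fold lower number from compound 3 to compound 4 (0.81 log units; beyond the scatter)) moves the number beyond the scatter, a kind of change the earlier compounds did not test. With chloro, the sulfonyl side chain sits within the scatter of the butyl group (a 1.9-fold lower number from compound 2 to compound 4 (0.28 log units; within the scatter)), and it stands well clear of the 3-hydroxyphenyl group (a 12-fold lower number from compound 1 to compound 4 (1.09 log units; beyond the scatter)). No measurement here explains why this swap has such an effect. From the compounds shown here alone, whether bromo or methyl on the same aromatic carbon would lower the number further remains open.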